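Adding a Trifluoromethyl Group to a Bare Anilide

A few compounds are considered here, and "the series" means these few. Any claim that something is new, unique, unknown or untested is made for them only; others in the source may bear on it.

Of the compounds shown here, three have been measured in a functional assay on PC-3 cells (Homo sapiens) for cytotoxicity, read by sulforhodamine B assay, with a stated time of 72 h; a lower number here means a stronger inhibitor of growth, a higher number a weaker inhibitor of growth. Compound 3 `O=C(Nc1ccccc1)C1CCc2ccccc2N1` carries an unsubstituted anilide and gives 110000 nM, the highest of the three numbers. Compound 2 `COc1ccc(NC(=O)C2CCc3ccccc3N2)cc1`, which bears a methoxy group on the anilide ring, gives 56900 nM; the step of a 1.9-fold higher number from compound 2 to compound 3 (0.29 log units; within the scatter) lies within the scatter. Compound 1 `O=C(Nc1ccccc1C(F)(F)F)C1CCc2ccccc2N1C(=O)c1ccccc1`, which carries both a trifluoromethyl group on the anilide ring and a benzoyl group on the ring nitrogen of the core, gives 5560 nM, a much lower number than compound 3, but it differs from compound 3 in two places, so the two values alone cannot be split between the two changes.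

Compound 4 `O=C(Nc1ccccc1C(F)(F)F)C1CCc2ccccc2N1` differs from compound 3 only by trifluoromethyl in place of hydrogen on an aromatic carbon. Going by the values given here, no measured step isolates this change: the one step available, the removal of a methoxy group, is within the scatter and concerns a different group. The values of compound 1 and compound 3 suggest that part of their wide gap may come with the trifluoromethyl group, so a lower number is expected for compound 4, though its size is uncertain. The expected step is a 3.7-fold lower number from compound 3 to compound 4 (0.56 log units; beyond the scatter). Compound 4 is estimated at 30000 nM, with a range from 8000 nM to 100000 nM.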

Compound 4, concentration for 50% growth inhibition: 53300 nM
Compound 4: the middle estimate sits 1.8-fold (0.25 log units) below what was measured, within the range that was stated.
By their numbers in this assay, from the lowest: compound 1; then compounds 4, 2 and 3 (each within the scatter of the next, the first and the last beyond it).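

In this assay, trifluoromethyl in place of hydrogen on an aromatic carbon, ortho to a large group, gives a 2.1-fold lower number from compound 3 to compound 4 (0.31 log units; beyond the scatter), so this change now has a reading of its own: a modest step, though one beyond the scatter. Compound 4 also separates the two changes that were tangled together in the comparison of compound 1 with compound 3, since removing only the benzoyl group from the ring nitrogen gives a 9.6-fold higher number from compound 1 to compound 4 (0.98 log units; beyond the scatter). Along this path, the benzoyl step is the larger of the two, so the trifluoromethyl group accounts for only the smaller part of the wide gap between compound 1 and compound 3. Nothing available here explains why either change moves the number as it does.

Still open is whether benzoyl on the ring nitrogen would give a similar step on the bare anilide of compound 3, since the step shown holds only with trifluoromethyl present. Also open, from the compounds shown here alone, is how other groups at this same place on the ring, such as a nitrile, an amine or a carboxylic acid, would compare with hydrogen and trifluoromethyl.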